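The compounds below may be only part of what the source reports. "The series", "measured", "known", "first", "only" and "open" are said of these compounds alone.

Measured so far in a functional assay on cells (Cancer cell lines, Homo sapiens) for inhibition; a higher number here means a weaker inhibitor of growth, a lower number a stronger inhibitor of growth:
compound 1 `O=Cc1c(-c2ccc([N+](=O)[O-])cc2)nc2sc(Cc3ccccc3)nn12`: 2900 nM
compound 2 `O=[N+]([O-])c1ccc(-c2nc3sc(Cc4ccccc4)nn3c2Br)cc1`: 3400 nM

Compound 1 has the lower of the two numbers in this assay, with compound 2 separated only by a 1.2-fold higher number from compound 1 to compound 2 (0.07 log units; within the scatter). That step exchanges a group on the shared core, not on the six-membered aromatic ring of carbon only.

Compound 3 `O=Cc1c(-c2ccc(Br)cc2)nc2sc(Cc3ccccc3)nn12` differs from compound 1 by bromo in place of nitro on an aromatic carbon. For the measured compounds named here, no measured step touches this ring, so nothing speaks directly to the change. In the absence of any bearing step, a shift of no more than the scatter is expected, a 1.0-fold higher number from compound 1 to compound 3 (0.01 log units; within the scatter). Compound 3 is therefore estimated at 3000 nM, within a range of 1000 nM to 9000 nM.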

Compound 3, concentration for 50% growth inhibition: 2200 nM
Compound 3: middle estimate off by 1.4-fold (0.13 log units), on the high side, within the range that was stated.
By their numbers in this assay, from the lowest: compounds 3, 1 and 2 (each within the scatter of the next).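

In this assay, bromo in place of nitro para to a large group gives a 1.3-fold lower number from compound 1 to compound 3 (0.12 log units; within the scatter) and so stays within the scatter. For the compounds shown here, this is the first reading at this ring position, and it shows that nitro is not needed for the growth inhibition seen with compound 1, since bromo serves as well here. No measurement shown offers an explanation for this result.

Still open, on these data alone, is whether an amine or a carboxylic acid in place of nitro would move the number beyond the scatter. Also open is whether the formyl and ring substituent changes combine, as no compound shown carries bromo at both places.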